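Swapping a chlorinated phenyl ring for a small dimethylisoxazole

The source may report more compounds than this note shows. Statements on the series, on what has been measured and on what is new or still open speak of the compounds shown alone.

Three measured compounds share one core and differ only in the aromatic group hung on its outer ring. Compound 1 `Cc1cccc(C)c1-c1cccc(COc2ccc(S(=O)(=O)CC(=O)O)cc2)c1` gives 66.1 nM in a functional assay on CHO cells for agonist activity at Free fatty acid receptor 1 (Homo sapiens), read by FLIPR and calcium flux; on this read-out higher numbers stand for an effect only at larger amounts of compound and lower numbers for an effect already at smaller amounts. Compound 2 `Cc1ccc(-c2cccc(COc3ccc(S(=O)(=O)CC(=O)O)cc3)c2)c(Cl)c1` gives 36.3 nM, and compound 3 `CCOc1ccc(-c2cccc(COc3ccc(S(=O)(=O)CC(=O)O)cc3)c2)c(Cl)c1` gives 51.3 nM. Compound 3 sits second highest of the three numbers, but every gap between them is small: a 1.3-fold lower number from compound 1 to compound 3 (0.11 log units; within the scatter), a 1.4-fold higher number from compound 2 to compound 3 (0.15 log units; within the scatter) and a 1.8-fold lower number from compound 1 to compound 2 (0.26 log units; within the scatter). Compound 4 `Cc1noc(C)c1-c1cccc(COc2ccc(S(=O)(=O)CC(=O)O)cc2)c1` takes the change (3,5-dimethyl-1,2-oxazol-4-yl in place of 2-chloro-4-ethoxyphenyl on an aromatic carbon). For the measured compounds named here, none of the measured steps tests this kind of exchange; they only vary substituents on a six-membered aromatic ring of carbon only, and all stayed within the scatter, so they say little about replacing that ring with a five-membered one. The expectation is a modest weakening, estimated as a 2.9-fold higher number from compound 3 to compound 4 (0.47 log units; beyond the scatter). Compound 4 is therefore expected to give about 150 nM in this assay, with a plausible range from 40 nM to 600 nM.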

Compound 4, half-maximal effective concentration: 269 nM
Compound 4: the middle estimate sits 1.8-fold (0.25 log units) below what was measured; low and high end bracket the measured number.
By their numbers in this assay, from the lowest: compounds 2, 3 and 1 (each within the scatter of the next); then compound 4.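

For the compounds shown here, at this position of the shared core, the three rings of carbon only stay within the scatter of one another in this assay, whereas 3,5-dimethyl-1,2-oxazol-4-yl is the first group to move the number beyond it. The exchange gives a 5.2-fold higher number from compound 3 to compound 4 (0.72 log units; beyond the scatter) and, measured against the other two compounds, a 7.4-fold higher number from compound 2 to compound 4 (0.87 log units; beyond the scatter) and a 4.1-fold higher number from compound 1 to compound 4 (0.61 log units; beyond the scatter), so replacing the whole ring counts for more here than changing the substituents on it did. Nothing at hand explains this rise.

The compounds shown leave open whether the higher number goes with the smaller five-membered ring or with the nitrogen and oxygen inside it. A thiophene at this position would help separate the two, and a pyridine would show how a six-membered ring containing nitrogen behaves.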